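Adding a Chlorine to a Fused Ring: Compound 4 Expected

A few compounds are considered here, and "the series" means these few. Any claim that something is new, unique, unknown or untested is made for them only; others in the source may bear on it.

Of the compounds shown here, three on one shared core have been tested in an assay on CHO cells for activation of soluble guanylate cyclase alpha1/beta1 complex (Homo sapiens), read by cGMP accumulation; on this read-out lower numbers stand for an effect already at smaller amounts and higher numbers for an effect only at larger amounts of compound. Compound 1 `CC1(C)C(=O)Nc2nc(-n3nc(CCCC(F)(F)F)c4cc(Cl)ccc43)nc(N)c21` gives 117000 nM, and compound 2 `CCCCc1nn(-c2nc(N)c3c(n2)NC(=O)C3(C)C)c2ccc(Cl)cc12` gives 47000 nM; the change of methyl for trifluoromethyl on the chain, a 2.5-fold lower number from compound 1 to compound 2 (0.40 log units; beyond the scatter), was a modest shift. Compound 3 `CC1(C)C(=O)Nc2nc(-n3nc(Cc4c(F)ccc(F)c4F)c4ccccc43)nc(N)c21` gives 2000 nM in this assay, the lowest of the three numbers, beyond the scatter from both others. Compound 4 `CC1(C)C(=O)Nc2nc(-n3nc(Cc4c(F)ccc(F)c4F)c4cc(Cl)ccc43)nc(N)c21` differs from compound 3 only by chloro in place of hydrogen on an aromatic carbon. Going by the values given here, no measured step changes this chlorine alone; compounds 1 and 2 carry it but also bear a different chain, so their numbers cannot be separated from that chain. Without a guide, a step within the scatter is expected, no change at the digits printed from compound 3 to compound 4 (within the scatter). Compound 4 is therefore estimated at 2000 nM, within a range from 700 nM to 6000 nM.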

Compound 4, half-maximal effective concentration: 7300 nM
Beside the measured number, compound 4's estimate is 3.7-fold (0.56 log units) below it; the measured number lies above the stated range.
By their numbers in this assay, from the lowest: compound 3; then compound 4; then compound 2; then compound 1.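

In this assay this aromatic carbon is not indifferent to substitution: chloro in place of hydrogen, with nothing else changed, gives a 3.7-fold higher number from compound 3 to compound 4 (0.56 log units; beyond the scatter) on its own. With the chlorine kept, 2,3,6-trifluorophenyl still gives a 6.4-fold lower number from compound 2 to compound 4 (0.81 log units; beyond the scatter) in place of propyl and a 16-fold lower number from compound 1 to compound 4 (1.20 log units; beyond the scatter) in place of 3,3,3-trifluoropropyl, so the chlorine does not cancel the lower numbers seen with that group. No measurement shown gives a reason for these shifts. Open, from the compounds shown here alone, is whether a fluoro, a methyl or a methoxy on this carbon would behave like chloro. Also open, going by these compounds, is whether chloro gives a similar step on the chains of compound 1 and compound 2.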